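Halogen and Alkoxy Swap on an Amide-Linked Piperazine Sulfonamide

A few compounds are considered here, and "the series" means these few. Any claim that something is new, unique, unknown or untested is made for them only; others in the source may bear on it.

Of the compounds shown here, two built on a shared core have been measured in an assay on HEK293 cells for inhibition of potassium channel subfamily T member 1 (Homo sapiens), read by thallium flux; a lower number here means a stronger inhibitor, a higher number a weaker inhibitor. Compound 1 `COc1ccc(F)cc1NC(=O)CN1CCN(S(=O)(=O)N2CCC(C)CC2)CC1` gives 4900 nM. Compound 2 `CCOc1ccc(Cl)cc1NC(=O)CN1CCN(S(=O)(=O)N2CCC(C)CC2)CC1` gives 7100 nM, the higher of the two numbers, but the gap is within the scatter of the method, so the two cannot be told apart. Going by the values given here, the only step so far, a 1.4-fold higher number from compound 1 to compound 2 (0.16 log units; within the scatter), exchanges both the alkoxy group and the halogen on the aryl ring attached to the amide nitrogen and changes the number by no more than the usual spread.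

Compound 3 `COc1ccc(Br)cc1NC(=O)CN1CCN(S(=O)(=O)N2CCC(C)CC2)CC1` is not yet measured. It differs from compound 2 in one place: 5-bromo-2-methoxyphenyl in place of 5-chloro-2-ethoxyphenyl on an amide-type nitrogen. Among the compounds with values here, this change again alters both the alkoxy group and the halogen, and the one step on record for that kind of exchange stayed within the scatter. Within the data shown here, no measured step supports a shift beyond the scatter in either direction in this assay, so the step of a 1.3-fold lower number from compound 2 to compound 3 (0.11 log units; within the scatter) is expected to be small. Compound 3 is therefore estimated at 5500 nM, with a range from 2500 nM to 12000 nM.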

Compound 3, half-maximal inhibitory concentration: 1400 nM
Estimate against measurement, compound 3: 3.9-fold (0.59 log units) above, outside the stated range (below it).
By their numbers in this assay, from the lowest: compound 3; then compounds 1 and 2 (each within the scatter of the next).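

In this assay the aryl group on the amide-type nitrogen proved able to shift the number beyond the scatter, as a 5.1-fold lower number from compound 2 to compound 3 (0.71 log units; beyond the scatter) shows, whereas the earlier pair had stayed within it. The plainest reading comes from the single exchange of bromo in place of fluoro on an aromatic carbon with the methoxy kept, which gives a 3.5-fold lower number from compound 1 to compound 3 (0.54 log units; beyond the scatter) and so shows that the halogen alone can produce a step of this size among these compounds, leaving compound 3 the strongest inhibitor of the three. Nothing measured here explains why the bromo compound gives the lower number.

The step from compound 2 changes the alkoxy group and the halogen together, and the compounds shown do not divide its size between the two; an aryl group pairing ethoxy with bromo, or methoxy with chloro, would be needed to do that. Going by these compounds, whether iodo, a trifluoromethyl group or a nitrile in place of the bromo would give a lower or a higher number also stays open.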